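Methylsulfanyl for selenium on the shared core: compound 3

The compounds below may be only part of what the source reports. "The series", "measured", "known", "first", "only" and "open" are said of these compounds alone.

compound 1 `CSc1ccc(CNc2nc([SeH])nc3ccccc23)cc1` — > 100000 nM
compound 2 `[SeH]c1nc(NCc2ccccc2)c2ccccc2n1` — > 100000 nM

In a functional assay on HTB-54 cells (Homo sapiens) for cytotoxicity, read by MTT assay, with a stated time of 72 h (on this read-out lower numbers stand for stronger inhibition of growth and higher numbers for weaker inhibition of growth), compound 1 reaches only a limit of the assay, and > 100000 nM is that limit rather than a number. Compound 2 likewise sits at a limit, > 100000 nM being the assay limit and not a number. For the measured compounds named here, the single measured step, a step that the two limits leave unreadable from compound 1 to compound 2, therefore cannot be read, since both values rest at the limit of > 100000 nM in this assay, at which 2 of the 2 values shown sit.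

Compound 3 `CSc1ccc(CNc2nc(SC)nc3ccccc23)cc1` differs from compound 1 by a group of 2 heavy atoms (1 carbon, 1 sulfur; no ring) in place of one selenium atom, on an aromatic carbon. Going by the values given here, no measured step touches this exchange, and the one step on record gives no size. Compound 3 is thus expected to remain at the limit as well, with an estimate of 150000 nM and a range from 60000 nM to 400000 nM. The implied step is expected to be a step that the limit leaves unreadable from compound 1 to compound 3, an expectation only.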

Compound 3, concentration for total growth inhibition: 44500 nM
Beside the measured number, compound 3's estimate is 3.4-fold (0.53 log units) above it; measured number outside the range, below it.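

In this assay, for the compounds shown here, the position between two ring nitrogen atoms gives the first readable step: methylsulfanyl in place of selenium gives an at least 2.2-fold lower number from compound 1 to compound 3 (0.35 log units; beyond the scatter) and so moves the series off the limit. Going by these compounds, compound 1 gives > 100000 nM as a limit of the assay and not as a number, so the true size of this step stays open on one side. The step from compound 1 to compound 2 cannot be read, and most of the series still rests on one limit: the limit of > 100000 nM in this assay, at which 2 of the 3 values shown sit.

On these data alone, whether the lower number belongs to methylsulfanyl itself or would also follow from another group at this position, such as an amine or a longer ethylsulfanyl chain, remains open. The compounds shown also leave open what the methylsulfanyl on the other ring of compound 3 contributes to this value.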